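Pyrrolidin-1-yl in place of piperidin-1-yl: compound 4 expected

The source may hold more compounds than are shown below. What is called first, only, known or untested is meant among the compounds shown, and "the series" means these compounds.

Measured so far in a functional assay on MDA-MB-435S cells (Homo sapiens) for antiproliferative activity, read by MTT assay, with a stated time of 72 h; a higher number here means a weaker inhibitor, a lower number a stronger inhibitor:
compound 1 `O=c1c(CSC(=S)N2CCCC2)coc2ccccc12` gives 3800 nM
compound 2 `Cc1ccc2c(=O)c(CSC(=S)N3CCCC3)coc2c1` gives 1900 nM
compound 3 `O=c1c(CSC(=S)N2CCCCC2)coc2cc(Cl)ccc12` gives 240 nM

Compound 3 holds the lowest number of the three in this assay; its distance from compound 2 and from compound 1 lies beyond the scatter. For the measured compounds named here, the only single-point step among the measured compounds, a 2.0-fold lower number from compound 1 to compound 2 (0.30 log units; within the scatter), concerns a methyl on the aromatic ring and is within the scatter.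

Compound 4 `O=c1c(CSC(=S)N2CCCC2)coc2cc(Cl)ccc12` arises from compound 3 by pyrrolidin-1-yl in place of piperidin-1-yl on a thiocarbonyl carbon. Going by the values given here, no measured pair isolates this change: compound 1 and compound 3 differ both in the ring on the thiocarbonyl carbon and in the chloro substituent, so their values cannot be split between the two. The step of a 2.0-fold lower number from compound 1 to compound 2 (0.30 log units; within the scatter) does not bear on it. The expectation therefore rests on compound 3 alone, with wide bounds that reach toward the numbers of compound 1 and compound 2; the expected step is a 2.1-fold higher number from compound 3 to compound 4 (0.32 log units; beyond the scatter). Compound 4 is estimated at 500 nM in this assay, within 150 nM to 2000 nM.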

Compound 4, half-maximal inhibitory concentration: 6400 nM
The estimate for compound 4 lay 13-fold (1.11 log units) below the measured number; the measured number lies above the stated range.
By their numbers in this assay, from the lowest: compound 3; then compounds 2, 1 and 4 (each within the scatter of the next, the first and the last beyond it).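

In this assay, the low number of compound 3 turns out to be tied to its piperidin-1-yl ring and not to the chloro substituent alone: pyrrolidin-1-yl in place of piperidin-1-yl on the thiocarbonyl carbon gives a 27-fold higher number from compound 3 to compound 4 (1.43 log units; beyond the scatter). With pyrrolidin-1-yl held constant, adding the chloro substituent to the unsubstituted core stays within the scatter, at a 1.7-fold higher number from compound 1 to compound 4 (0.23 log units; within the scatter), while chloro in place of methyl gives a 3.4-fold higher number from compound 2 to compound 4 (0.53 log units; beyond the scatter). No available evidence accounts for the size of the ring exchange.

The compounds shown leave open whether piperidin-1-yl would have the same effect on the core of compound 1, without the chloro substituent. They also leave open how a morpholin-4-yl ring or an open-chain dimethylamino group on the thiocarbonyl carbon would compare.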